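This account rests on a few compounds, and the source may have more. Where it says the series, first, only, none or still open, it means among the compounds named here.

In a physicochemical assay for lipophilicity, using the shake flask method (on this read-out higher numbers stand for higher lipophilicity and lower numbers for lower lipophilicity), three compounds built on a shared core have been measured. Compound 1 `CC(C)Oc1cc(Oc2ccc(S(C)(=O)=O)cc2)cc(-c2cccc(=O)[nH]2)c1` gives 2.82, compound 2 `CC(C)Oc1cc(Oc2ccc(S(C)(=O)=O)cc2)cc(-c2nccc(=O)[nH]2)c1` gives 2.14, and compound 3 `Cc1cnc(-c2cc(Oc3ccc(S(C)(=O)=O)cc3)cc(OC(C)C)c2)[nH]c1=O` gives 2.68. Two steps fix the place of compound 3 on this scale: a number 0.14 log units lower from compound 1 to compound 3 (within the scatter), and a number 0.54 log units higher from compound 2 to compound 3 (beyond the scatter). It therefore sits level with compound 1 and apart from compound 2. The third step, a number 0.68 log units lower from compound 1 to compound 2 (beyond the scatter), exchanges one ring-bearing group for another and says little about the change now in question.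

Compound 4 `CCc1cnc(-c2cc(Oc3ccc(S(C)(=O)=O)cc3)cc(OC(C)C)c2)[nH]c1=O` follows from compound 3 by one small change: methyl in place of hydrogen on a saturated chain carbon bound to an aromatic carbon. The same difference, cut one bond further out, reads methyl to ethyl. Among the measured compounds shown here, no measured pair shows this exact change. For the measured compounds named here, the closest precedent is methyl in place of hydrogen on an aromatic carbon, which gave a number 0.54 log units higher from compound 2 to compound 3 (beyond the scatter). Going by the values given here, this single step is the only guide, and it involves a different place of attachment, so a step in the same direction but of somewhat smaller size seems the reasonable expectation. The expected step is a number 0.37 log units higher from compound 3 to compound 4 (beyond the scatter). For compound 4 the estimated value is 3.05, with an expected range from 2.8 to 3.35.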

Compound 4, distribution coefficient: 3.11
For compound 4 the middle estimate is 0.06 log units below the measured one; measured number inside the range.
By their numbers in this assay, from the lowest: compound 2; then compounds 3, 1 and 4 (each within the scatter of the next, the first and the last beyond it).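

Across the two steps at this position, the change from hydrogen to methyl to ethyl moves the reading upward both times. The added methyl on the saturated chain carbon bound to an aromatic carbon gives a number 0.43 log units higher from compound 3 to compound 4 (beyond the scatter), which continues the direction of the earlier a number 0.54 log units higher from compound 2 to compound 3 (beyond the scatter), and the two changes together give in all a number 0.97 log units higher from compound 2 to compound 4 (beyond the scatter), the widest gap among the compounds shown. The comparison with the other ring-bearing group, a number 0.29 log units higher from compound 1 to compound 4 (within the scatter), shows that ethyl brings this series level with that group in this assay, where methyl had already done so, and so the two cannot be told apart on this scale. No measurement at hand accounts for any of these steps.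

Going by these compounds, whether the upward run continues with a longer chain such as propyl, or holds for a branched group such as isopropyl, remains open. Equally open, on these data alone, is what an amine, a hydroxymethyl or a carboxylic acid would do at this position, since only hydrogen, methyl and ethyl are compared there.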